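Phenyl Exchanged for Cyclohexyl on the Urea Nitrogen

The source may hold more compounds than are shown below. What is called first, only, known or untested is meant among the compounds shown, and "the series" means these compounds.

Compound 2 `Cc1nc(N)sc1CCCN/C(N)=N/C(=O)Nc1ccccc1` stands highest of the two numbers in an assay on membranes from Sf9 cells for displacement of a labelled ligand from histamine H2 receptor (Homo sapiens), read by scintillation counting, with a stated time of 60 min (a higher number here means a weaker inhibitor, a lower number a stronger inhibitor), where compound 2 gives 3160 nM. For the measured compounds named here, its nearest neighbour, compound 1 `CCCNC(=O)/N=C(\N)NCCCc1sc(N)nc1C`, gives 105 nM in this assay, and the single measured step, a 30-fold higher number from compound 1 to compound 2 (1.48 log units; beyond the scatter), bears directly on the change at hand. Compound 3 `Cc1nc(N)sc1CCCN/C(N)=N/C(=O)NC1CCCCC1` differs from compound 2 by cyclohexyl in place of phenyl on an amide-type nitrogen. Because a 30-fold higher number from compound 1 to compound 2 (1.48 log units; beyond the scatter) came with phenyl in place of propyl, and cyclohexyl is a non-aromatic ring rather than an aromatic one, the step of a 7.9-fold lower number from compound 2 to compound 3 (0.90 log units; beyond the scatter) is expected to be a moderate move back toward the number of compound 1. Compound 3 is therefore estimated at 400 nM, within a range from 100 nM to 1600 nM.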

Compound 3, inhibition constant: 170 nM
Beside the measured number, compound 3's estimate is 2.4-fold (0.37 log units) above it; the range from low to high includes it.
By their numbers in this assay, from the lowest: compounds 1 and 3 (each within the scatter of the next); then compound 2.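

On the amide-type nitrogen, the aromatic and the non-aromatic six-membered rings are not interchangeable: in this assay, cyclohexyl in place of phenyl gives a 19-fold lower number from compound 2 to compound 3 (1.27 log units; beyond the scatter), although both groups have the same heavy-atom count. Cyclohexyl in place of propyl gives a 1.6-fold higher number from compound 1 to compound 3 (0.21 log units; within the scatter), so among these compounds, a ring at this position does not by itself bring the high number seen with compound 2. Nothing available here explains the difference between the two rings. On these data alone, whether a smaller ring such as cyclopropyl or a longer chain such as hexyl would match compound 1 and compound 3 remains open. So does whether a methoxy group on the phenyl ring would change the number of compound 2.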